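Rebuilding the fused ring on the ether side

The source may hold more compounds than are shown below. What is called first, only, known or untested is meant among the compounds shown, and "the series" means these compounds.

Among the compounds with values here, compound 3 `COc1cc(OCC(=O)Nc2cccc(NC(=O)c3ccc(N(C)C)cc3)c2)ccc1C=O` is the only member of the set with a number in an assay on isolated protein for inhibition of Rho-associated protein kinase 1 (Homo sapiens), read by scintillation counting, radiometric assay and 33P incorporation, with a stated time of 40 min, in the presence of a further agent that is not named here; on this read-out lower numbers stand for stronger inhibition and higher numbers for weaker inhibition; in this assay compound 3 gives 3740 nM. Compound 1 `CN(C)c1ccc(C(=O)Nc2cccc(NC(=O)COc3ccc4c(c3)NC(=O)CC4)c2)cc1` reaches only a limit of the assay, since in this assay compound 1 gives > 10000 nM. Compound 2 `CN(C)c1ccc(C(=O)Nc2cccc(NC(=O)COc3ccc4c(c3)CCC(=O)N4)c2)cc1` likewise reaches only a limit of the assay, since in this assay compound 2 gives > 10000 nM. Compound 4 `CN(C)c1ccc(C(=O)Nc2cccc(NC(=O)COc3ccc4c(c3)OCCO4)c2)cc1` differs from compound 3 by a group of 10 heavy atoms (8 carbon, 2 oxygen; one six-membered non-aromatic ring with 2 hetero atoms, one six-membered aromatic ring of carbon only) in place of a group of 10 heavy atoms (8 carbon, 2 oxygen; one six-membered aromatic ring of carbon only), on an oxygen on a saturated carbon. Within the data shown here, the two measured steps that bear on this change are an at least 2.6-fold lower number from compound 1 to compound 3 (0.42 log units; beyond the scatter) and an at least 2.6-fold lower number from compound 2 to compound 3 (0.42 log units; beyond the scatter), each moving from a fused pair of rings on the ether oxygen to the single aromatic ring of compound 3, and in view of the limit of > 10000 nM in this assay, at which 2 of the 3 values shown sit, their true size cannot be read. Compound 4 restores a fused pair of rings at that oxygen, so a step back toward weaker inhibition is expected, as a 2.1-fold higher number from compound 3 to compound 4 (0.33 log units; beyond the scatter). Compound 4 is therefore estimated at 8000 nM in this assay, with a range of 3000 nM to 30000 nM.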

Compound 4, half-maximal inhibitory concentration: > 10000 nM
Compound 4: only a limit was reported (the forecaster's own chance of this, stated with the estimate: 45%); middle value at least 1.2-fold (0.09 log units) from the limit.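

In this assay compound 4 gives > 10000 nM, which is a limit of the assay and not a number. The new result is an at least 2.6-fold higher number from compound 3 to compound 4 (0.42 log units; beyond the scatter), a change that keeps the same 10 heavy atoms and the same hydrogen-bond counts on the oxygen on a saturated carbon, so a difference at this position appears even with those counts unchanged. With 2,3-dihydro-1,4-benzodioxin-6-yl, a fused pair of rings without nitrogen also sits at the limit, and the steps linking compound 4 to compound 1 and compound 2 cannot be read: the limit of > 10000 nM in this assay, at which 3 of the 4 values shown sit.

As far as these compounds go, it remains open how a plain phenyl ring, or an aromatic ring carrying an amine or a carboxylic acid, would read at this oxygen. From the compounds shown here alone, the order among the three fused pairs of rings also stays unknown.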